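Enlarging the amine substituent on compound 2

A few compounds are considered here, and "the series" means these few. Any claim that something is new, unique, unknown or untested is made for them only; others in the source may bear on it.

Of the compounds shown here, two with a shared core have been measured in an assay on HeLa cells for displacement of a labelled ligand from 5-hydroxytryptamine receptor 6 (Homo sapiens); on this read-out lower numbers stand for stronger inhibition and higher numbers for weaker inhibition. Compound 1 `CN1CCC(n2cc(S(=O)(=O)c3cccc(F)c3)c3cccnc32)C1` gives 1.4 nM. Compound 2 `CN1CCCC(n2cc(S(=O)(=O)c3cccc(F)c3)c3cccnc32)C1` gives 4.7 nM, the higher of the two numbers; the step of a 3.4-fold higher number from compound 1 to compound 2 (0.53 log units; beyond the scatter) is the only measured one, and it concerns the ring that carries the amine, not the group on the amine nitrogen.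

Compound 3 `CC(C)N1CCCC(n2cc(S(=O)(=O)c3cccc(F)c3)c3cccnc32)C1` differs from compound 2 by isopropyl in place of methyl on an amine nitrogen in a ring. Within the data shown here, no measured pair shows what such a change does on this core, so the single known step offers only a loose reference for how far numbers move when the amine-bearing part is altered. The expectation for compound 3 is therefore a modest rise in the number, a 1.9-fold higher number from compound 2 to compound 3 (0.28 log units; within the scatter), with a range that includes no change beyond the scatter.

Compound 3 is estimated to give 9 nM in this assay, expected to lie between 2.5 nM and 30 nM.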

Compound 3, inhibition constant: 3.4 nM
The estimate for compound 3 lay 2.6-fold (0.42 log units) above the measured number; the measured number falls inside the stated range.
By their numbers in this assay, from the lowest: compound 1; then compounds 3 and 2 (each within the scatter of the next).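

In this assay, among these compounds, the first measured change to the group on the amine nitrogen, rather than to the ring that carries it, gives a 1.4-fold lower number from compound 2 to compound 3 (0.14 log units; within the scatter); on the six-membered ring, then, replacing methyl with isopropyl adds two heavy atoms at this position without moving the number beyond the scatter. The ring-and-substituent change taken as a whole gives a 2.4-fold higher number from compound 1 to compound 3 (0.39 log units; beyond the scatter), so compound 1, with its 1-methylpyrrolidin-3-yl group, keeps a number below those of both piperidine compounds by more than the scatter. No evidence is available that bears on this result, so the data describe the size of these steps and offer no explanation for them.

As far as these compounds go, this rests on a single pair on one ring, so it remains open whether isopropyl would behave in the same way on the five-membered ring of compound 1, as a 1-isopropylpyrrolidin-3-yl group. Also open, from the compounds shown here alone, is how the number would respond on the amine nitrogen to a plain hydrogen or to a larger group such as benzyl.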